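Methyl to Methoxy on the Amino-Linked Phenyl Ring

A few compounds are considered here, and "the series" means these few. Any claim that something is new, unique, unknown or untested is made for them only; others in the source may bear on it.

Measured compounds:
compound 1, `CCOC(=O)c1c(-c2ccc(Cl)cc2)cc(-c2ccccc2)nc1Nc1ccccc1`, 73.9%
compound 2, `CCOC(=O)c1c(-c2ccc(Cl)cc2)cc(-c2ccccc2)nc1Nc1ccc(C)cc1`, 32.6%

In a functional assay on the whole organism (strain Wister albino) for inhibition, with Rattus norvegicus as the target, read by paw edema, with stated times of 1 h and 2 h, at a dose of 50 mg/kg by the intraperitoneal route (on this read-out higher numbers stand for more inhibition at the one dose given (going by the name of the read-out) and lower numbers for less inhibition), compound 1 gives 73.9%, while compound 2 gives 32.6%. Compound 2 thus stands lowest of the two numbers shown, and its only neighbour is compound 1, separated by a number 41.3 percentage points lower from compound 1 to compound 2 (beyond the scatter), the one step measured here, which came with methyl in place of hydrogen on an aromatic carbon.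

Compound 3, `CCOC(=O)c1c(-c2ccc(Cl)cc2)cc(-c2ccccc2)nc1Nc1ccc(OC)cc1`, differs from compound 2 by methoxy in place of methyl on an aromatic carbon. Among the compounds with values here, no measured step bears directly on methoxy in place of methyl; the single known step concerns a different change, so it gives the size of one substituent effect but no direction for this one. The expectation is therefore set wide.

Compound 3 is expected to give about 45% in this assay, with a range from 20% to 75%. The step this estimate implies, a number 12.4 percentage points higher from compound 2 to compound 3 (beyond the scatter), is expected to be modest, with no direction stated with confidence.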

Compound 3, a percentage reported as inhibition, in the whole organism at one dose (the size of the read-out at that dose, not a potency): 61.1%
For compound 3 the middle estimate is 16.1 percentage points below the measured one; the measured number falls inside the stated range.
By their numbers in this assay, from the lowest: compound 2; then compound 3; then compound 1.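

At this place, para to a large group, the read-out in this assay depends on which group is present and not only on whether hydrogen has been replaced. Methoxy in place of methyl gives a number 28.5 percentage points higher from compound 2 to compound 3 (beyond the scatter) and so recovers much of what methyl lost, while methoxy in place of hydrogen still gives a number 12.8 percentage points lower from compound 1 to compound 3 (beyond the scatter) and leaves both substituted compounds under the hydrogen compound. Nothing available explains why methoxy and methyl part in this way.

Whether any group at this place can match or pass hydrogen remains open, since only methyl and methoxy are shown there, and a hydroxyl, an amine or a fluorine could fall anywhere on this scale. Also open, going by these compounds, is how a carboxylic acid in place of the ethyl ester would read.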